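The source may hold more compounds than are shown below. What is called first, only, known or untested is meant among the compounds shown, and "the series" means these compounds.

Compound 1 `Cn1c(=O)c2[nH]c(Cc3ccc(OCCCCl)cc3)nc2n(C)c1=O`: > 30 nM
Compound 2 `Cn1c(=O)c2[nH]c(-c3ccc(OCCCN4CCN(Cc5ccccc5Cl)CC4)cc3)nc2n(C)c1=O`: 1.85 nM

In an assay on CHO cells for displacement of a labelled ligand from adenosine receptor A1 (Homo sapiens), read by scintillation counting, with a stated time of 3 h (on this read-out higher numbers stand for weaker inhibition and lower numbers for stronger inhibition), compound 1 gives only > 30 nM, which is a limit of the assay and not a number (the limit of > 30 nM in this assay, at which 1 of the 2 values shown sits). Compound 2 shows 1.85 nM in this assay; the two structures differ in more than one place, so nothing beyond the two values themselves can be read from that pair. Compound 3 `Cn1c(=O)c2[nH]c(Cc3ccc(OCCCn4ccnc4)cc3)nc2n(C)c1=O` differs from compound 1 in one place: 1H-imidazol-1-yl in place of chloro on a saturated chain carbon, three bonds along the chain from an oxygen on an aromatic ring. With compound 1 known only as a limit, the size of the step cannot be anchored; a modest gain beyond the scatter is expected, written as a step that the limit leaves unreadable from compound 1 to compound 3. Compound 3 is estimated at 100 nM, within 20 nM to 600 nM.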

Compound 3, inhibition constant: > 30 nM
Compound 3: only a limit was reported; the forecaster's own chance of this, stated with the estimate: 40%; the middle value does not contradict the limit.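

In this assay compound 3 gives > 30 nM, a limit and not a number. For the compounds shown here, compound 1 is also known only as a limit, so no step between compound 1 and compound 3 can be read. From the compounds shown here alone, whether 1H-imidazol-1-yl in place of chloro changes the inhibition at all stays open.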